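This account rests on a few compounds, and the source may have more. Where it says the series, first, only, none or still open, it means among the compounds named here.

Measured compounds:
compound 1 `N#CC1=C(NCC(=O)N2CCCC2)N(c2ccccc2)C(=O)N2CCCCC(N3CCCC3)C12` — 40.1%
compound 2 `N#CC1=C(NCN2CCCCC2)N(c2ccccc2)C(=O)N2CCCCC(N3CCCC3)C12` — 29.7%
compound 3 `N#CC1=C(/N=C/Nc2ccccc2)N(c2ccccc2)C(=O)N2CCCCC(N3CCCC3)C12` — 35.2%

In a functional assay on the whole organism (strain albino) for inhibition, with Rattus norvegicus as the target, read by paw edema, with a stated time of 1 h, at a dose of 20 mmol/kg by the intraperitoneal route (on this read-out lower numbers stand for less inhibition and higher numbers for more inhibition at the one dose given (going by the name of the read-out)), compound 3 stands second highest of the three. Compound 1 is nearest: a number 4.9 percentage points lower from compound 1 to compound 3 (within the scatter). Compound 2 is furthest: a number 5.5 percentage points higher from compound 2 to compound 3 (within the scatter). Compound 4 `N#CC1=C(N)N(c2ccccc2)C(=O)N2CCCCC(N3CCCC3)C12` differs from compound 3 in one place: one nitrogen atom in place of a group of 9 heavy atoms (7 carbon, 2 nitrogen; one six-membered aromatic ring of carbon only), on a double-bonded ring carbon. Among the compounds with values here, no measured step bears directly on this change; the three known steps all exchange one group of comparable size for another on the same double-bonded ring carbon, and only a number 10.4 percentage points lower from compound 1 to compound 2 (beyond the scatter) exceeds the scatter. Given 35.2% for compound 3, a step of a number 2.2 percentage points lower from compound 3 to compound 4 (within the scatter) is expected, within the scatter. Compound 4 is therefore estimated at 33%, in the range 18% to 48%.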

Compound 4, a percentage reported as inhibition, in the whole organism at one dose (the size of the read-out at that dose, not a potency): 77.9%
For compound 4 the middle estimate is 44.9 percentage points below the measured one; measured number above the stated range.
By their numbers in this assay, from the lowest: compounds 2, 3 and 1 (each within the scatter of the next, the first and the last beyond it); then compound 4.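

In this assay, the free amino group on the double-bonded ring carbon sets compound 4 above every other compound shown: a number 42.7 percentage points higher from compound 3 to compound 4 (beyond the scatter), a number 48.2 percentage points higher from compound 2 to compound 4 (beyond the scatter) and a number 37.8 percentage points higher from compound 1 to compound 4 (beyond the scatter). Exchanging one substituent on this nitrogen for another moved the number far less, the largest such exchange being a number 10.4 percentage points lower from compound 1 to compound 2 (beyond the scatter), so the bare amino group separates the series more than any choice of substituent does. Nothing measured here explains the rise. On these data alone, it remains open whether a small group on this nitrogen, such as methyl or acetyl, would keep the high number. As far as these compounds go, whether a hydroxyl group could replace the amino group also remains open.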